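This account rests on a few compounds, and the source may have more. Where it says the series, first, only, none or still open, it means among the compounds named here.

Measured compounds:
- compound 1, `COc1ccc(/C=C/C(=O)c2ccccc2-c2ccc(F)cc2)cc1`: 61 nM
- compound 2, `COc1ccc(/C=C/C(=O)c2ccccc2-c2ccc(F)nc2)cc1`: 330 nM
- compound 3, `COc1cc(C(=O)/C=C/c2ccccc2-c2ccc(F)cc2)ccc1O`: 4200 nM

Of the compounds shown here, three have been tested in a functional assay on SW480 cells (Homo sapiens) for antiproliferative activity, read by sulforhodamine B assay, with a stated time of 48 h; on this read-out lower numbers stand for stronger inhibition and higher numbers for weaker inhibition. Compound 1 gives 61 nM in this assay, and compound 2 gives 330 nM. The two differ by one change, (6-fluoropyridin-3-yl in place of 4-fluorophenyl on an aromatic carbon), which made a step of a 5.4-fold higher number from compound 1 to compound 2 (0.73 log units; beyond the scatter). Compound 3, with a different core, gives 4200 nM in this assay; how its core differs from that of compound 1 is not broken down here.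

Compound 4, `COc1cc(C(=O)/C=C/c2ccccc2-c2ccc(F)nc2)ccc1O`, has not yet been measured. It carries the same change relative to compound 3, namely (6-fluoropyridin-3-yl in place of 4-fluorophenyl on an aromatic carbon), at the same kind of place. Among the measured compounds shown here, because the one earlier instance of this change gave a 5.4-fold higher number from compound 1 to compound 2 (0.73 log units; beyond the scatter), compound 4 is expected to sit at a higher number than compound 3, and the step from compound 3 to compound 4 is estimated at roughly a 4.3-fold higher number from compound 3 to compound 4 (0.63 log units; beyond the scatter). A single prior example leaves the expectation uncertain, so the range is kept wide. Compound 4 is estimated at 18000 nM, between 6000 nM and 55000 nM, in this assay.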

Compound 4, half-maximal inhibitory concentration: 8500 nM
For compound 4 the middle estimate is 2.1-fold (0.33 log units) above the measured one, within the range that was stated.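

In this assay the replacement of 4-fluorophenyl by 6-fluoropyridin-3-yl again weakened inhibition, with a 2.0-fold higher number from compound 3 to compound 4 (0.31 log units; beyond the scatter). The direction of the change therefore held on both cores, but its size did not carry over unchanged: the same change on two cores in this assay, a 5.4-fold higher number (0.73 log units; beyond the scatter) from compound 1 to compound 2 and a 2.0-fold higher number (0.31 log units; beyond the scatter) from compound 3 to compound 4, 2.7-fold (0.43 log units) apart, beyond the scatter of two such steps. These two pairs show that the swap raised the number on each core tested, yet they do not explain why the size differs, and they cannot tell how the change would behave on any further core.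

The compounds shown leave open how other groups would compare at this place on the two cores, such as a plain phenyl, a 4-chlorophenyl or a 6-methoxypyridin-3-yl. They also leave open whether an amine or a carboxylic acid on that ring would be tolerated in this series, and whether either core would respond to such groups as it did to the fluorinated rings.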